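Swapping the acid-bearing ring on a four-carbon linker

This account rests on a few compounds, and the source may have more. Where it says the series, first, only, none or still open, it means among the compounds named here.

Measured so far:
- compound 1, `Cc1c(OCCCCOc2ccc(Cl)c(C(=O)O)c2)ccc(C(=O)CC(C)(C)C)c1O`, 87 nM
- compound 2, `Cc1ccc(C(=O)O)cc1OCCCCOc1ccc(C(=O)CC(C)(C)C)c(O)c1C`, 512 nM

In an assay for positive allosteric modulation of metabotropic glutamate receptor 2 (Rattus norvegicus) (on this read-out lower numbers stand for an effect already at smaller amounts and higher numbers for an effect only at larger amounts of compound), compound 1 gives 87 nM, while compound 2 gives 512 nM, the highest of the two numbers. Among the measured compounds shown here, the one step with a measurement, a 5.9-fold higher number from compound 1 to compound 2 (0.77 log units; beyond the scatter), shows that exchanging the acid-bearing aryl group at the end of the chain moves the read-out well beyond the scatter. For the measured compounds named here, compound 3, `Cc1c(OCCCCOc2ccc(C(=O)O)cc2F)ccc(C(=O)CC(C)(C)C)c1O`, keeps the whole of the shared core and changes only that end group: 4-carboxy-2-fluorophenyl in place of 5-carboxy-2-methylphenyl on an oxygen on a saturated carbon. Since this is the same kind of exchange as the one measured, a step of comparable size seems plausible, and with a halogen returning to the ring a move back toward compound 1 appears somewhat more likely than a further rise. The expected step is therefore a 2.0-fold lower number from compound 2 to compound 3 (0.31 log units; beyond the scatter), and compound 3 is estimated at 250 nM, within a range of 80 nM to 800 nM.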

Compound 3, half-maximal effective concentration: 75 nM
Compound 3: the middle estimate sits 3.3-fold (0.52 log units) above what was measured; the whole stated range lies above it.
By their numbers in this assay, from the lowest: compounds 3 and 1 (each within the scatter of the next); then compound 2.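

At this place, on an oxygen on a saturated carbon, a 6.8-fold lower number from compound 2 to compound 3 (0.83 log units; beyond the scatter) in this assay shows that replacing 5-carboxy-2-methylphenyl with 4-carboxy-2-fluorophenyl can bring the read-out down as far as the earlier step had raised it. With a 1.2-fold lower number from compound 1 to compound 3 (0.06 log units; within the scatter), the 4-carboxy-2-fluorophenyl and 3-carboxy-4-chlorophenyl groups cannot be told apart in this read-out, although their halogens and the positions in their names differ. Nothing available explains why these end groups behave this way.

Between compound 2 and compound 3, the methyl gives way to fluorine and the carboxylic acid changes place on the ring, so the two changes cannot be separated. Going by these compounds, how a tetrazole in place of the carboxylic acid, or a plain 4-carboxyphenyl group, would read at this place remains open.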